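The source may report more compounds than this note shows. Statements on the series, on what has been measured and on what is new or still open speak of the compounds shown alone.

Three compounds have been measured in a functional assay on MCF7 cells (Homo sapiens) for antiproliferative activity, read by MTT assay, with a stated time of 24 h; on this read-out lower numbers stand for stronger inhibition and higher numbers for weaker inhibition:

compound 1, `COc1cc(C2CC(c3ccccc3)=NN2c2ccc(-c3ccccc3)nn2)cc(OC)c1OC`: 70000 nM
compound 2, `COc1cc(C2CC(c3ccc(Cl)cc3)=NN2c2ccc(-c3ccccc3)nn2)cc(OC)c1OC`: 100000 nM
compound 3, `COc1ccc(C2=NN(c3ccc(-c4ccccc4)nn3)C(c3ccccc3)C2)cc1`: > 100000 nM, which is a limit of this assay and not a number

Compound 1 and compound 2 share one core and differ in a single place: chloro in place of hydrogen on an aromatic carbon. In this assay that change gave a 1.4-fold higher number from compound 1 to compound 2 (0.15 log units; within the scatter). Compound 3 is built on another core, and the difference between the two cores of compound 1 and compound 3 is not broken down here. For compound 3 this assay returned only a limit, (the limit of > 100000 nM in this assay, at which 1 of the 3 values shown sits), so its value sets no number.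

Compound 4, `COc1ccc(C2=NN(c3ccc(-c4ccccc4)nn3)C(c3ccc(Cl)cc3)C2)cc1`, has not yet been measured in this assay. It stands to compound 3 exactly as compound 2 stands to compound 1: chloro in place of hydrogen on an aromatic carbon. The surroundings of the place are described in the same words for both pairs, so this is the same change made on the second core.

The earlier step was within the scatter, and compound 3 already sits at a limit, so the step from compound 3 to compound 4 is expected to be about a step that the limit leaves unreadable from compound 3 to compound 4, an expectation resting on a 1.4-fold higher number from compound 1 to compound 2 (0.15 log units; within the scatter) and on the limit reported for compound 3. Compound 4 is therefore estimated at about 150000 nM, expected to fall between 80000 nM and 300000 nM, with a good chance that this assay again reports only a limit.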

Compound 4, half-maximal inhibitory concentration: 58000 nM
Estimate against measurement, compound 4: 2.6-fold (0.41 log units) above; the measured number lies below the stated range.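

In this assay, chloro in place of hydrogen on the core of compound 3, the change from phenyl to 4-chlorophenyl, gave an at least 1.7-fold lower number from compound 3 to compound 4 (0.23 log units; that floor lies within the scatter), and this figure is only a floor on the size of the step. Set beside the same change on the core of compound 1, the result leaves the question of transfer unsettled: the same change on two cores in this assay, a 1.4-fold higher number (0.15 log units; within the scatter) from compound 1 to compound 2 and an at least 1.7-fold lower number (0.23 log units; that floor lies within the scatter) from compound 3 to compound 4; the limit leaves it open whether they differ. The two pairs therefore show neither that the change carries from one core to the other with the same size nor that it behaves differently on the two cores, and the comparison depends on a single reading that is a limit of the assay and not a number: the limit of > 100000 nM in this assay, at which 1 of the 4 values shown sits.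

The compounds shown leave open what an amine, a carboxylic acid or a longer chain would do in place of chloro on this aromatic ring, on either core. They also leave open whether a number for compound 3 within the range of the assay would bring the two steps together or set them apart, and whether any such pattern would hold on a third core.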